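A few compounds are considered here, and "the series" means these few. Any claim that something is new, unique, unknown or untested is made for them only; others in the source may bear on it.

Compound 1 `CC(C)NC(=O)NC1CC(C)(C)Oc2ccc(Cl)cc21` and compound 2 `CCOC(=O)NC1CC(C)(C)Oc2ccc(Cl)cc21` share one core and differ only in the group attached to the carbonyl carbon. In a functional assay on T98G cells (Homo sapiens) for inhibition, read by MTT assay, with a stated time of 72 h (on this read-out lower numbers stand for stronger inhibition and higher numbers for weaker inhibition), compound 1 gives > 100000 nM, which is a limit of the assay rather than a measured number. For compound 2 there is no number at all in this assay, since its result is recorded as "not determined" (no result reported), so compound 2 stands without a single value of its own. The one result shown for this series sits at the limit of > 100000 nM in this assay, at which 1 of the 2 values shown sits.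

Compound 3 `CC1(C)CC(NC(=O)Nc2cccc(Cl)c2)c2cc(Cl)ccc2O1` is the next step from compound 2: (3-chlorophenyl)amino in place of ethoxy on a carbonyl carbon. Going by the values given here, with no measured pair to draw on, the step in this assay is expected to be modest, leaning toward stronger inhibition than the limit seen for compound 1, but not by much. Compound 3 is therefore estimated at 50000 nM, within a range from 10000 nM to 150000 nM.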

Compound 3, half-maximal inhibitory concentration: 25000 nM
Estimate against measurement, compound 3: 2.0-fold (0.30 log units) above; low and high end bracket the measured number.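

Putting 3-chlorophenyl in place of isopropyl on the amide-type nitrogen gives, in this assay, an at least 4.0-fold lower number from compound 1 to compound 3 (0.60 log units; beyond the scatter) and so shows that the group at this place can move the read-out. Going by these compounds, compound 3 gives a number, whereas compound 1 stays at a limit of the assay, so the true size of this step remains unknown: the limit of > 100000 nM in this assay, at which 1 of the 3 values shown sits. The step between compound 2 and compound 3, where ethoxy leaves, cannot be read, as compound 2 has no result.

On these data alone, it remains open whether the gain follows the aromatic ring or its chlorine. A plain phenyl group and a cyclohexyl group on the same nitrogen would help to separate these two possibilities.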